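Enlarging the Amide Substituent on an Adenosine Receptor Ligand

The compounds below may be only part of what the source reports. "The series", "measured", "known", "first", "only" and "open" are said of these compounds alone.

compound 1: `CCNC(=O)[C@H]1O[C@@H](n2cnc3c(NCc4cccc(I)c4)nc(Cl)nc32)[C@H](O)[C@@H]1O` — 0.891 nM
compound 2: `O=C(NC1CC1)[C@H]1O[C@@H](n2cnc3c(NCc4cccc(I)c4)nc(Cl)nc32)[C@H](O)[C@@H]1O` — 2.95 nM
compound 3: `O=C(NC1CCC1)[C@H]1O[C@@H](n2cnc3c(NCc4cccc(I)c4)nc(Cl)nc32)[C@H](O)[C@@H]1O` — 18.2 nM

Three compounds share one core and differ only in the group carried on the amide-type nitrogen. In an assay on CHO cells for displacement of a labelled ligand from adenosine receptor A3 (Homo sapiens) (a lower number here means a stronger inhibitor, a higher number a weaker inhibitor), compound 1 gives 0.891 nM, compound 2 gives 2.95 nM and compound 3 gives 18.2 nM. Compound 3 therefore stands at the highest number of the three, and both of its steps to the others lie beyond the scatter, so it is the weakest binder in this set. The measured steps all point the same way: a 3.3-fold higher number from compound 1 to compound 2 (0.52 log units; beyond the scatter), a 20-fold higher number from compound 1 to compound 3 (1.31 log units; beyond the scatter) and a 6.2-fold higher number from compound 2 to compound 3 (0.79 log units; beyond the scatter). Each time the group on this nitrogen grew, the number rose.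

Compound 4 is `O=C(NCc1cccc(C(F)(F)F)c1)[C@H]1O[C@@H](n2cnc3c(NCc4cccc(I)c4)nc(Cl)nc32)[C@H](O)[C@@H]1O`. Compared with compound 3 the change is 3-(trifluoromethyl)benzyl in place of cyclobutyl on an amide-type nitrogen. Within the data shown here, this is a far larger group than any measured here, and no measured step covers an aromatic substituent at this position, so the size of the effect is uncertain. Given that the steps from compound 1 through compound 3 rose with every enlargement, the number for compound 4 is expected to rise again, as in an 11-fold higher number from compound 3 to compound 4 (1.04 log units; beyond the scatter). Compound 4 is estimated at 200 nM, with a range from 30 nM to 1500 nM.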

Compound 4, inhibition constant: 355 nM
For compound 4 the middle estimate is 1.8-fold (0.25 log units) below the measured one; the range from low to high includes it.
By their numbers in this assay, from the lowest: compound 1; then compound 2; then compound 3; then compound 4.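

Placing an aromatic ring on this amide-type nitrogen continues the upward trend in this assay, with a 20-fold higher number from compound 3 to compound 4 (1.29 log units; beyond the scatter), and the distance from the smaller groups becomes much wider, with a 120-fold higher number from compound 2 to compound 4 (2.08 log units; beyond the scatter) and a 400-fold higher number from compound 1 to compound 4 (2.60 log units; beyond the scatter). Across all four compounds the number rises in the order ethyl, cyclopropyl, cyclobutyl, 3-(trifluoromethyl)benzyl, with no compound going against that order, and compound 4 is the weakest binder of the set. Nothing available here explains why the number rises.

The compounds shown do not separate the contribution of the benzyl group from that of its trifluoromethyl group, so a plain benzyl group would be the direct comparison. Also open, on these data alone, is where a methyl group or a longer chain such as butyl would fall in this order.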